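The source may report more compounds than this note shows. Statements on the series, on what has been measured and on what is new or still open speak of the compounds shown alone.

Measured so far in a functional assay on T-24 cells (Homo sapiens) for antiproliferative activity, read by MTT assay, with a stated time of 48 h; on this read-out lower numbers stand for stronger inhibition and higher numbers for weaker inhibition:

compound 1, `Cc1ccc(NC(=O)Nc2cccc(CNc3nccnc3Cl)c2)cc1C`, gives 8930 nM
compound 2, `O=C(Nc1cccc(CNc2nccnc2Cl)c1)Nc1cccc2ccccc12`, gives > 40000 nM

Among the compounds with values here, compound 1 stands as the only value in this assay that is a plain number. Compound 2 gives > 40000 nM, which is a limit of the assay and not a number; that is the limit of > 40000 nM in this assay, at which 1 of the 2 values shown sits.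

Within the data shown here, no pair of measured compounds differs in one place, so no measured step is available for comparison. Compound 3, `O=C(Nc1cccc(CNc2nccnc2Cl)c1)Nc1ccccc1Cl`, is not yet measured. It differs from compound 1 by 2-chlorophenyl in place of 3,4-dimethylphenyl on an amide-type nitrogen. The two measured values only show that a 3,4-dimethylphenyl group gives a number while a naphthyl group gives a limit; what a 2-chlorophenyl group does is open. In this assay a modest weakening from compound 1 is expected as the estimated step of a 1.7-fold higher number from compound 1 to compound 3 (0.23 log units; within the scatter), though one that may stay within the scatter. Compound 3 is therefore estimated at 15000 nM, with a range from 5000 nM to 40000 nM.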

Compound 3, half-maximal inhibitory concentration: 6680 nM
Compound 3: the middle estimate sits 2.2-fold (0.35 log units) above what was measured; measured number inside the range.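

In this assay, the group on the amide-type nitrogen can go from 3,4-dimethylphenyl to 2-chlorophenyl without a change that can be read: a 1.3-fold lower number from compound 1 to compound 3 (0.13 log units; within the scatter). Within the data shown here, two different substituted phenyl groups now give plain numbers at this place, and these lie within the scatter of each other, which the single number of compound 1 could not show. Compound 2, carrying the naphthyl group, remains a limit of the assay and not a number, so no step to it can be read: the limit of > 40000 nM in this assay, at which 1 of the 3 values shown sits.

The compounds shown leave open how a plain phenyl, a cyclohexyl or a pyridyl group would behave at this place. They also leave open whether a carboxylic acid or an amine on the phenyl ring would keep a number in this range.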